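Butyl to oxolanylcarbonyl on the ring amine nitrogen

A few compounds are considered here, and "the series" means these few. Any claim that something is new, unique, unknown or untested is made for them only; others in the source may bear on it.

Compound 2 `CCCCN1CCc2nc(C#Cc3ccccc3)sc2C1` is measured in an assay on HEK293 cells for negative allosteric modulation of metabotropic glutamate receptor 5 (Homo sapiens), read by FLIPR, with a stated time of 1 h (a lower number here means a stronger inhibitor, a higher number a weaker inhibitor), and gives > 10000 nM, which is a limit of the assay rather than a number. It therefore stands at the limit of > 10000 nM in this assay, at which 2 of the 3 values shown sit. Compound 1 `COc1ccccc1C#Cc1nc2c(s1)C(=O)NCC2` likewise gives only the limit > 10000 nM in this assay. For the measured compounds named here, compound 3 `Fc1cccc(C#Cc2nc3c(s2)CN(C2CCC2)CC3)c1` gives 200 nM in this assay, the one numerical value in the set. Compound 4 `O=C(C1CCCO1)N1CCc2nc(C#Cc3ccccc3)sc2C1` is not yet measured. It differs from compound 2 by (oxolan-2-yl)carbonyl in place of butyl on an amine nitrogen in a ring. Going by the values given here, no pair of measured compounds differs in a single place, so the size of this change has no measured precedent. A shift toward a measurable value is expected but uncertain, so the step from compound 2 to compound 4 is estimated as an at least 2.5-fold lower number from compound 2 to compound 4 (0.39 log units; beyond the scatter). Compound 4 is expected to give 4000 nM, within 700 nM to 20000 nM, in this assay.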

Compound 4, half-maximal inhibitory concentration: > 10000 nM
Compound 4 was reported as a limit (the forecaster's own chance of this, stated with the estimate: 50%); middle value at least 2.5-fold (0.39 log units) from the limit.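

The step between compound 2 and compound 4 cannot be read, since both compounds give only a limit of the assay. Left open is whether butyl or (oxolan-2-yl)carbonyl on the ring amine nitrogen gives the stronger inhibitor.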